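The source may hold more compounds than are shown below. What is called first, only, known or untested is meant among the compounds shown, and "the series" means these compounds.

Notes on the series. For the measured compounds named here, in a functional assay on HT-29 cells (Homo sapiens) for antiproliferative activity, read by sulforhodamine B assay, with a stated time of 48 h (a lower number here means a stronger inhibitor, a higher number a weaker inhibitor), compound 1 (`Cc1ccc(OS(=O)(=O)c2ccc(N3CCN(C)C3=O)cc2)c(C)c1`) gives 3000 nM as the lowest of the two numbers so far. Compound 2 (`COc1ccc(OS(=O)(=O)c2ccc(N3CCN(C)C3=O)cc2)cc1OC`) gives 12000 nM in this assay and lies above compound 1 by a gap beyond the usual scatter.

Compound 3 (`Cc1ccc(OS(=O)(=O)c2ccc(N3CCN(C)C3=O)cc2)cc1`) has not yet been measured. It departs from compound 1 in one place, and hydrogen in place of methyl on an aromatic carbon is the whole change, with hydrogen in place of methyl on an aromatic carbon, so that 2,4-dimethylphenyl becomes 4-methylphenyl. Going by the values given here, no measured pair isolates this change, so the expectation is weakly grounded. The expected step of a 1.7-fold higher number from compound 1 to compound 3 (0.22 log units; within the scatter) is a small rise in the number, toward a weaker inhibitor, of about the size of the scatter. For compound 3 the estimated value is 5000 nM in this assay, with 1800 nM to 14000 nM as the expected range.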

Compound 3, half-maximal inhibitory concentration: > 100000 nM
Compound 3: only a limit was reported (the forecaster's own chance of this, stated with the estimate: 10%); middle value at least 20-fold (1.30 log units) from the limit.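

In this assay, for the compounds shown here, the methyl group ortho to a large group carries far more weight than the earlier compounds could show: hydrogen in place of methyl on this aromatic carbon gives an at least 33-fold higher number from compound 1 to compound 3 (1.52 log units; beyond the scatter). A change of one carbon, from 2,4-dimethylphenyl to 4-methylphenyl, is enough to separate a measured value from a reported limit in this series. Compound 3 has only a limit and no number, so the full size of the step remains undefined: the limit of > 100000 nM in this assay, at which 1 of the 3 values shown sits.

Going by these compounds, whether the place ortho to a large group accepts only methyl, or also an ethyl group, a chlorine atom or an amine, stays open. On these data alone, it is equally open whether the other methyl group, on the aromatic carbon meta to this place, matters to a similar degree.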